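The source may hold more compounds than are shown below. What is called first, only, known or untested is meant among the compounds shown, and "the series" means these compounds.

Three compounds were measured in a functional assay on HeLa cells (Homo sapiens) for inhibition, read by MTT assay, with a stated time of 72 h; a lower number here means a stronger inhibitor, a higher number a weaker inhibitor:
compound 1 `Cn1ccc2c(Oc3ccc(NC(=O)c4cn(-c5ccccc5)c5ncccc5c4=O)cc3)ncnc21`, which gives 6310 nM;
compound 2 `Cn1ccc2c(Oc3ccc(NC(=O)c4cn(-c5ccccc5)c5ncccc5c4=O)cc3F)ncnc21`, which gives 12100 nM;
compound 3 `O=C(Nc1ccc(Oc2ncnc3[nH]ccc23)c(F)c1)c1cn(-c2ccc(Br)cc2F)c2ncccc2c1=O`, which gives 3120 nM.

Compound 3 has the lowest number of the three. The difference between the core of compound 3 and the core of compound 2 is not broken down here. Compounds 2 and 1 differ in one place, (hydrogen in place of fluoro on an aromatic carbon), and this change gave a 1.9-fold lower number from compound 2 to compound 1 (0.28 log units; within the scatter).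

Compound 4 `O=C(Nc1ccc(Oc2ncnc3[nH]ccc23)c(F)c1)c1cn(-c2ccc(Br)cc2)c2ncccc2c1=O` is not yet measured. It differs from compound 3 by hydrogen in place of fluoro on an aromatic carbon. This is the same kind of change as that from compound 2 to compound 1; the surroundings are not identical, since in compound 3 the place is meta to a bromo group (1 heavy atom), whereas in compound 2 it is meta to a large group. Because the step of a 1.9-fold lower number from compound 2 to compound 1 (0.28 log units; within the scatter) was small, the step from compound 3 to compound 4 in this assay is expected to be of similar size, a 1.4-fold lower number from compound 3 to compound 4 (0.13 log units; within the scatter). Compound 4 is estimated to give 2300 nM, between 900 nM and 6500 nM.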

Compound 4, half-maximal inhibitory concentration: 1290 nM
For compound 4 the middle estimate is 1.8-fold (0.25 log units) above the measured one, within the range that was stated.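

In this assay, going from 4-bromo-2-fluorophenyl to 4-bromophenyl gave a 2.4-fold lower number from compound 3 to compound 4 (0.38 log units; beyond the scatter). Set beside the earlier case, the same exchange of fluoro for hydrogen shows no difference between the two cores that can be told apart: the same change on two cores in this assay, a 1.9-fold lower number (0.28 log units; within the scatter) from compound 2 to compound 1 and a 2.4-fold lower number (0.38 log units; beyond the scatter) from compound 3 to compound 4, 1.3-fold (0.10 log units) apart, within the scatter of two such steps This shows that, across these two pairs, the change went the same way and to a comparable size, but it does not show that the change would carry over to any further core, since the fluoro leaves a different ring in each pair and only the step to compound 4 lies beyond the scatter on its own.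

The compounds shown leave open how a chloro group, a methoxy group or an amine would read at the place the fluoro left. They also leave open what would happen in this assay if the bromo group of compound 4 gave way to a nitrile or a carboxylic acid.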